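A few compounds are considered here, and "the series" means these few. Any claim that something is new, unique, unknown or untested is made for them only; others in the source may bear on it.

Of the compounds shown here, three sharing one core have been measured in a functional assay on MGC-803 cells (Homo sapiens) for inhibition, read by MTT assay, with a stated time of 72 h; a lower number here means a stronger inhibitor, a higher number a weaker inhibitor. Compound 1 `CCCSc1nc2nc(C)cc(N3CC[C@@H](C)[C@@H](N(C)c4ncnc5[nH]ccc45)C3)n2n1` carries a propyl chain on its sulfur, and in this assay compound 1 gives 15500 nM. Compound 2 `Cc1cc(N2CC[C@@H](C)[C@@H](N(C)c3ncnc4[nH]ccc34)C2)n2nc(SCc3cc(Cl)ccc3Cl)nc2n1` instead carries a 2,5-dichlorophenyl on the saturated chain carbon bound to the sulfur, and compound 2 gives 9850 nM. Compound 3 `Cc1cc(N2CC[C@@H](C)[C@@H](N(C)c3ncnc4[nH]ccc34)C2)n2nc(SCc3ccccc3)nc2n1` has a plain phenyl there, and compound 3 gives 5870 nM. Among these three, compound 2 sits in the middle: it is separated from compound 1 by a 1.6-fold lower number from compound 1 to compound 2 (0.20 log units; within the scatter) and from compound 3 by a 1.7-fold lower number from compound 2 to compound 3 (0.22 log units; within the scatter), so neither gap is a real difference. Within the data shown here, the only step beyond the scatter is a 2.6-fold lower number from compound 1 to compound 3 (0.42 log units; beyond the scatter).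

The next compound, compound 4 `Cc1cc(N2CC[C@@H](C)[C@@H](N(C)c3ncnc4[nH]ccc34)C2)n2nc(SCCCc3ccccc3)nc2n1`, differs from compound 2 by phenethyl in place of 2,5-dichlorophenyl on a saturated chain carbon bound to a sulfur. Among the measured compounds shown here, two steps bear on this. Exchanging the 2,5-dichlorophenyl for phenyl gave a 1.7-fold lower number from compound 2 to compound 3 (0.22 log units; within the scatter), and replacing ethyl with phenyl gave a 2.6-fold lower number from compound 1 to compound 3 (0.42 log units; beyond the scatter). Compound 4 keeps a phenyl ring but places it on a longer chain, so it lies between those cases. The expected change for compound 4 is therefore a 1.4-fold lower number from compound 2 to compound 4 (0.15 log units; within the scatter), small and inside the scatter. Compound 4 is estimated at 7000 nM, expected to fall between 3000 nM and 16000 nM.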

Compound 4, half-maximal inhibitory concentration: > 100000 nM
Compound 4 was reported as a limit (the forecaster's own chance of this, stated with the estimate: 3%); middle value at least 14-fold (1.15 log units) from the limit.
By their numbers in this assay, from the lowest: compounds 3, 2 and 1 (each within the scatter of the next, the first and the last beyond it). At a limit, above all of these: compound 4.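

In this assay, compound 4 is reported only as a limit, not as a number: the limit of > 100000 nM in this assay, at which 1 of the 4 values shown sits. Even read as bounds, the steps are an at least 10-fold higher number from compound 2 to compound 4 (1.00 log units; beyond the scatter), an at least 17-fold higher number from compound 3 to compound 4 (1.23 log units; beyond the scatter) and an at least 6.4-fold higher number from compound 1 to compound 4 (0.80 log units; beyond the scatter), so the 3-phenylpropyl group on the sulfur stands apart from the benzyl groups and from the plain propyl chain. Among these compounds, compound 3 and compound 4 both carry an unsubstituted phenyl ring, and so do not differ in the ring itself, which shows that having a phenyl ring at this position is not enough and that its place along the chain matters, something the small spread among the earlier compounds, no wider than a 2.6-fold lower number from compound 1 to compound 3 (0.42 log units; beyond the scatter), gave no sign of.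

The compounds shown do not reveal how the activity falls away as the chain grows, and a 2-phenylethyl group on the sulfur would fill the gap between the benzyl of compound 3 and the 3-phenylpropyl of compound 4. On these data alone, it also remains open whether the loss belongs to the ring at the end of the chain or to the chain itself, which a plain longer chain such as hexyl, or an amine at the chain end, could help to separate.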